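From hydroxymethyl to ethoxycarbonyl on a three-membered ring

This account rests on a few compounds, and the source may have more. Where it says the series, first, only, none or still open, it means among the compounds named here.

In a functional assay on SW480 cells (Homo sapiens) for cytotoxicity, read by MTT assay, with a stated time of 48 h (on this read-out lower numbers stand for stronger inhibition and higher numbers for weaker inhibition), compound 1 `COc1cc([C@@H]2C[C@@]2(CO)C(=O)Nc2ccccc2)cc(OC)c1OC` gives 76800 nM, the higher of the two exact numbers. Compound 2 `COc1cc([C@H]2C[C@@]2(CO)C(=O)Nc2ccccc2)cc(OC)c1OC`, which differs only in configuration as drawn, has only a limit of > 100000 nM. Compound 3 `COc1cc([C@@H]2C[C@@]2(CO)C(=O)Nc2ccccc2Cl)cc(OC)c1OC` gives 10700 nM. Compound 4 `CCOC(=O)[C@@]1(C(=O)Nc2ccccc2)C[C@H]1c1cc(OC)c(OC)c(OC)c1` carries ethoxycarbonyl in place of hydroxymethyl on a saturated ring carbon. Neither measured step touches that group. One is an at least 1.3-fold higher number from compound 1 to compound 2 (0.11 log units; that floor lies within the scatter), a change of configuration, and the other is a 7.2-fold lower number from compound 1 to compound 3 (0.86 log units; beyond the scatter), with chloro in place of hydrogen on an aromatic carbon. Starting from compound 1 at 76800 nM, no step beyond the scatter is expected in this assay, and the expected step is a 1.3-fold lower number from compound 1 to compound 4 (0.11 log units; within the scatter). For compound 4 the estimate is 60000 nM, within an expected range of 20000 nM to 100000 nM.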

Compound 4, half-maximal inhibitory concentration: > 100000 nM
Compound 4 was reported as a limit (the forecaster's own chance of this, stated with the estimate: 30%); middle value at least 1.6-fold (0.22 log units) away from the limit.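

In this assay, this is the first change shown at this saturated ring carbon, and swapping hydroxymethyl for ethoxycarbonyl gives an at least 1.3-fold higher number from compound 1 to compound 4 (0.11 log units; that floor lies within the scatter). Compound 4 gives > 100000 nM, which is a limit of the assay. The swap therefore brings no lower number, but the true size of the step cannot be read, and the assay offers little room at this end: the limit of > 100000 nM in this assay, at which 2 of the 4 values shown sit.

Open, from the compounds shown here alone, is how a carboxylic acid or an aminomethyl group at this carbon would read. Also open, going by these compounds, is whether ethoxycarbonyl combined with the chloro of compound 3 would give a number that can be measured.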